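A few compounds are considered here, and "the series" means these few. Any claim that something is new, unique, unknown or untested is made for them only; others in the source may bear on it.

Compound 3, `COc1ccc(Oc2nc(Nc3ccc(C#N)cc3)nc3ccccc23)cc1`, stands second highest of the three numbers available in an ADME assay on MT4 cells (Homo sapiens) for cytotoxicity, read by MTT assay, with a stated time of 4 days (a lower number here means that less compound is tolerated, a higher number that more compound is tolerated), where compound 3 gives 340000 nM. Its nearest neighbour is compound 2, `Cc1cccc(Oc2nc(Nc3ccc(C#N)cc3)nc3ccccc23)c1`, which in this assay gives 355000 nM; the two are separated only by a 1.0-fold lower number from compound 2 to compound 3 (0.02 log units; within the scatter). Furthest away is compound 1, `N#Cc1ccc(Nc2nc(Oc3ccccc3Cl)c3ccccc3n2)cc1`, which gives 38000 nM, so that moving from it to compound 3 reads as an 8.9-fold higher number from compound 1 to compound 3 (0.95 log units; beyond the scatter).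

Compound 4 is `N#Cc1ccc(Nc2nc(Oc3ccc(F)cc3)c3ccccc3n2)cc1`. Relative to compound 3 the change is fluoro in place of methoxy on an aromatic carbon; read one bond further out, the 4-methoxyphenoxy group becomes a 4-fluorophenoxy group.

Going by the values given here, three measured steps touch the aryl ether. The step of a 9.3-fold higher number from compound 1 to compound 2 (0.97 log units; beyond the scatter) and the step of an 8.9-fold higher number from compound 1 to compound 3 (0.95 log units; beyond the scatter) both left the 2-chlorophenyl of compound 1 behind and were modest. The step of a 1.0-fold lower number from compound 2 to compound 3 (0.02 log units; within the scatter) swapped 3-methylphenyl for 4-methoxyphenyl and changed nothing beyond the scatter. Among the compounds with values here, no measured step exchanges methoxy for fluoro, so the expectation rests on the observation that compound 1, the only halogen-bearing ether, sits lowest. Compound 4 is therefore expected to fall somewhat below compound 3, at roughly a 1.7-fold lower number from compound 3 to compound 4 (0.23 log units; within the scatter). Compound 4 is estimated at 200000 nM, within a range from 60000 nM to 400000 nM.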

Compound 4, half-maximal cytotoxic concentration: > 351000 nM
Compound 4: no number, only a limit; the forecaster's own chance of this, stated with the estimate: 10%; middle value at least 1.7-fold (0.24 log units) from the limit.
By their numbers in this assay, from the lowest: compound 1; then compounds 3 and 2 (each within the scatter of the next).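

In this assay compound 4 gives no number, only a limit: the limit of > 351000 nM in this assay, at which 1 of the 4 values shown sits. This shows that a halogen on the aryl ether does not by itself bring the number down, which compound 1, the only halogen-bearing ether until now, could not separate from the effect of its 2-chlorophenyl group: fluoro in place of methoxy at this place, para to a large group, gives an at least 1.0-fold higher number from compound 3 to compound 4 (0.01 log units; that floor lies within the scatter), while the 4-fluorophenyl in place of 2-chlorophenyl gives an at least 9.2-fold higher number from compound 1 to compound 4 (0.96 log units; beyond the scatter). Among the four compounds, the low number therefore stays with compound 1 alone, and the step from compound 2 to compound 4 cannot be read through the limit.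

The limit leaves open how high compound 4 really lies, and so whether fluoro and methoxy differ at all at this place in this assay. Also open, on these data alone, is whether the low number of compound 1 follows from the chloro itself or from where it sits on the ring, and how a 4-chlorophenyl group or an amine on the same ring would read.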